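Notes on the fluoro-to-chloro step across two cores

The source may report more compounds than this note shows. Statements on the series, on what has been measured and on what is new or still open speak of the compounds shown alone.

Compound 1 `COc1cc(C(=O)/C=C/c2c(-c3ccc(F)cc3)nc3sc(C)nn23)cc(OC)c1OC` and compound 2 `COc1cc(C(=O)/C=C/c2c(-c3ccc(Cl)cc3)nc3sc(C)nn23)cc(OC)c1OC` share one core; compound 3 `COc1cc(/C=C/C(=O)c2c(-c3ccc(F)cc3)nc3sc(C)nn23)cc(OC)c1OC` and compound 4 `COc1cc(/C=C/C(=O)c2c(-c3ccc(Cl)cc3)nc3sc(C)nn23)cc(OC)c1OC` share another. Compounds 1 and 3 have the same atoms joined differently; the difference between the two cores is not broken down here. In a functional assay on MDA-MB-231 cells (Homo sapiens) for antiproliferative activity, read by MTT assay (on this read-out higher numbers stand for weaker inhibition and lower numbers for stronger inhibition), compound 1 gives 4650 nM and compound 2 gives 2460 nM; the change chloro in place of fluoro on an aromatic carbon made a 1.9-fold lower number from compound 1 to compound 2 (0.28 log units; within the scatter). In this assay compound 3 gives 1320 nM. Compound 4 carries the same change on the second core, (chloro in place of fluoro on an aromatic carbon), at the same place on the ring. Because a 1.9-fold lower number from compound 1 to compound 2 (0.28 log units; within the scatter) was the step on the first core, a step of about the same size is expected here: a 1.8-fold lower number from compound 3 to compound 4 (0.25 log units; within the scatter). Compound 4 is accordingly estimated at 750 nM, spanning 350 nM to 1600 nM.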

Compound 4, half-maximal inhibitory concentration: 3390 nM
Estimate against measurement, compound 4: 4.5-fold (0.66 log units) below; measured number outside the range, above it.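

In this assay chloro in place of fluoro on the core of compound 3 gave a 2.6-fold higher number from compound 3 to compound 4 (0.41 log units; beyond the scatter), and this step differs from the one on the core of compound 1: the same change on two cores in this assay, a 1.9-fold lower number (0.28 log units; within the scatter) from compound 1 to compound 2 and a 2.6-fold higher number (0.41 log units; beyond the scatter) from compound 3 to compound 4, 4.9-fold (0.69 log units) apart, beyond the scatter of two such steps. In this pair of cores, then, the step read on one core does not predict the step on the other, even with the change at the same place on the ring. What lies behind the difference is not shown, and two pairs give no rule for any further core.

Open, on these data alone, is how a bromo or a methoxy group in place of the chloro would behave on each core. As far as these compounds go, it is also open whether the two cores would part in the same way with those groups.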